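Nucleobase swap on a shared cytotoxicity read-out

A few compounds are considered here, and "the series" means these few. Any claim that something is new, unique, unknown or untested is made for them only; others in the source may bear on it.

Compound 1 `CN(C)c1ncnc2c1ncn2[C@@H]1O[C@H](CO[Si](C)(C)C(C)(C)C)[C@@]2(OS(=O)(=O)C=C2N)[C@H]1O[Si](C)(C)C(C)(C)C`: 15000 nM
Compound 2 `CC(C)(C)[Si](C)(C)OC[C@H]1O[C@@H](n2cnc3ncnc(O)c32)[C@H](O[Si](C)(C)C(C)(C)C)[C@]12OS(=O)(=O)C=C2N`: 15000 nM

In a functional assay on MT4 cells (Homo sapiens) for cytotoxicity (on this read-out lower numbers stand for higher toxicity in this test and higher numbers for lower toxicity in this test), compound 1 gives 15000 nM. In this assay compound 2 gives 15000 nM, so compound 2 stands level with compound 1 within the scatter. Among the compounds with values here, the one measured step, no change at the digits printed from compound 1 to compound 2 (within the scatter), swapped one bicyclic aromatic group for another on the saturated ring carbon and left the read-out unchanged.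

Compound 3 `CCn1cnc2ncn([C@@H]3O[C@H](CO[Si](C)(C)C(C)(C)C)[C@@]4(OS(=O)(=O)C=C4N)[C@H]3O[Si](C)(C)C(C)(C)C)c2c1=O` is the next member. Relative to compound 2 the change is a group of 12 heavy atoms (7 carbon, 4 nitrogen, 1 oxygen; one five-membered aromatic ring with 2 hetero atoms, one six-membered aromatic ring with 2 hetero atoms) in place of a group of 10 heavy atoms (5 carbon, 4 nitrogen, 1 oxygen; one five-membered aromatic ring with 2 hetero atoms, one six-membered aromatic ring with 2 hetero atoms), on a saturated ring carbon, again on a saturated ring carbon of a five-membered non-aromatic ring with 1 oxygen, next to the ring oxygen. Within the data shown here, the only comparable step, no change at the digits printed from compound 1 to compound 2 (within the scatter), bears directly on this change and was flat. No step beyond the scatter is therefore expected in this assay.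

Compound 3 is estimated at 15000 nM, with a range of 7000 nM to 32000 nM. The step from compound 2 to compound 3 is expected to be no change at the digits printed from compound 2 to compound 3 (within the scatter).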

Compound 3, half-maximal cytotoxic concentration: > 150000 nM
Compound 3: no number, only a limit (the forecaster's own chance of this, stated with the estimate: 25%); middle value at least 10-fold (1.00 log units) away from the limit.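

Compound 3 gives no number in this assay, only a limit: the limit of > 150000 nM in this assay, at which 1 of the 3 values shown sits.

The earlier exchange on this saturated ring carbon, next to the ring oxygen, gave no change at the digits printed from compound 1 to compound 2 (within the scatter), so the position had looked indifferent to the group it carries. The new compound shows that it is not, with an at least 10-fold higher number from compound 2 to compound 3 (1.00 log units; beyond the scatter) and an at least 10-fold higher number from compound 1 to compound 3 (1.00 log units; beyond the scatter), which on this read-out means lower toxicity in this test.

How far the true value of compound 3 lies past its limit stays unknown, and nothing shown says which feature of the entering group, with its 0 hydrogen-bond donors against 1 in the group it replaces, accounts for the step. From the compounds shown here alone, whether a primary amine or a longer chain such as butyl on the same bicyclic group would behave like compound 3 also remains open.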